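The source may hold more compounds than are shown below. What is called first, only, known or untested is meant among the compounds shown, and "the series" means these compounds.

In a functional assay on the whole organism for inhibition, with Cavia porcellus as the target (a higher number here means that more compound is needed for the effect, a lower number that less compound is needed), compound 1 (`COc1ccccc1OCC1SCCN1C(C)=O`) gives 46 mg/kg and compound 2 (`CCCC(=O)CC(=O)N1CCSC1COc1ccccc1OC`) gives 42 mg/kg as its reading, so the two lie within the scatter of each other. Compound 3 (`CNC(=O)CC(=O)N1CCSC1COc1ccccc1OC`) differs from compound 2 in one place, with methylamino in place of propyl on a carbonyl carbon. Among the compounds with values here, the only measured step (a 1.1-fold lower number from compound 1 to compound 2 (0.04 log units; within the scatter)) put propylcarbonyl in place of hydrogen on a saturated chain carbon bound to a carbonyl carbon. One small step is thin evidence, and no move beyond the scatter is expected in this assay. The expected move is (a 1.1-fold higher number from compound 2 to compound 3 (0.03 log units; within the scatter)) on this estimate. For compound 3 the estimated value is 45 mg/kg (range 20 mg/kg to 100 mg/kg).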

Compound 3, dose for half-maximal effect: 21 mg/kg
The estimate for compound 3 lay 2.1-fold (0.33 log units) above the measured number; the range from low to high includes it.
By their numbers in this assay, from the lowest: compounds 3, 2 and 1 (each within the scatter of the next, the first and the last beyond it).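

Placing methylcarbamoyl in place of hydrogen on a saturated chain carbon bound to a carbonyl carbon gives, in this assay, a 2.2-fold lower number from compound 1 to compound 3 (0.34 log units; beyond the scatter): this is the only step shown that lies beyond the scatter, and it is modest. Methylamino in place of propyl on a carbonyl carbon gives a 2.0-fold lower number from compound 2 to compound 3 (0.30 log units; within the scatter), so that swap alone makes no clear difference. No measurement here accounts for either step. Still open, going by these compounds, is whether the amide hydrogen of methylamino matters, which dimethylamino at that carbonyl carbon could test. On these data alone, an ethylamino or longer chain on the nitrogen is equally open.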